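Solubility notes on the imide series: compound 2 to compound 3

This account rests on a few compounds, and the source may have more. Where it says the series, first, only, none or still open, it means among the compounds named here.

The series is examined in a physicochemical assay for solubility, using the shake flask method, in simulated intestinal fluid, measured as kinetic solubility, with a stated time of 2 h, at 25 degrees C, at pH 6.5; on this read-out lower numbers stand for lower solubility and higher numbers for higher solubility. Compound 1 `Cc1nc(-c2nc(C(F)(F)F)no2)c(N)c2c1C(=O)N(Cc1ccccc1)C2=O` carries a benzyl group on the imide nitrogen and a trifluoromethyl-substituted oxadiazole. In this assay compound 1 gives < 5000 nM, which is a limit of the assay rather than a number. Compound 2 `Cc1noc(-c2nc(C)c3c(c2N)C(=O)N(Cc2ccc(OC(F)(F)F)cc2)C3=O)n1` carries the methyl-substituted oxadiazole and a trifluoromethoxy group on the benzyl ring. In this assay compound 2 gives < 5000 nM, again a limit and not a number. For the measured compounds named here, compound 2 therefore stands at the lower reporting edge, as does the one other value shown: the limit of < 5000 nM in this assay, at which 2 of the 2 values shown sit. Going by the values given here, no step between two measured compounds is available, so no measured size of change can be taken from the pair.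

Compound 3 `Cc1noc(-c2nc(C)c3c(c2N)C(=O)N(Cc2ccc(C(N)=O)cc2)C3=O)n1` is the next member, with carbamoyl in place of trifluoromethoxy on an aromatic carbon.

For compound 3 the expected step from compound 2 is an at least 1.8-fold higher number from compound 2 to compound 3 (0.25 log units; that floor lies within the scatter), an upward move that may or may not clear the scatter given the limit in hand. The solubility of compound 3 in this assay is estimated at 9000 nM, with a range from 2500 nM to 40000 nM.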

Compound 3, solubility: < 5000 nM
Compound 3: a limit, no number (the forecaster's own chance of this, stated with the estimate: 40%); at least 1.8-fold (0.25 log units) between middle value and limit.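

Compound 2 and compound 3 both return a limit and not a number, so the step between them, carbamoyl in place of trifluoromethoxy on an aromatic carbon, in this assay cannot be read. The compounds shown leave open how the three compare with one another in solubility, since all sit at one reporting edge: the limit of < 5000 nM in this assay, at which 3 of the 3 values shown sit.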